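Series notes: methyl to methoxy on the amide aryl

The compounds below may be only part of what the source reports. "The series", "measured", "known", "first", "only" and "open" are said of these compounds alone.

Of the compounds shown here, three of the shared core have been measured in a functional assay on SK-BR-3 cells (Homo sapiens) for antiproliferative activity, read by MTT assay, with a stated time of 72 h; on this read-out lower numbers stand for stronger inhibition and higher numbers for weaker inhibition. Compound 1 `Cc1cc(NCCN(C)C)nc2ccc(NC(=O)c3ccc(Cl)c(Cl)c3)cc12` gives 6670 nM. Among the compounds with values here, compound 3 `CCN(CC)c1cc(C)c2cc(NC(=O)c3ccc(Cl)c(Cl)c3)ccc2n1` gives 41200 nM, and the only single-point step so far, a 6.2-fold higher number from compound 1 to compound 3 (0.79 log units; beyond the scatter), moves the amine substituent on the core, not the amide aryl. Compound 2 `CCN1CCN(c2cc(C)c3cc(NC(=O)c4ccccc4C)ccc3n2)CC1` gives 29200 nM; it stands second highest of the three numbers, with compound 3 within the scatter of it and compound 1 beyond the scatter, lower.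

Compound 4 `CCN1CCN(c2cc(C)c3cc(NC(=O)c4ccccc4OC)ccc3n2)CC1` differs from compound 2 by methoxy in place of methyl on an aromatic carbon. Within the data shown here, no measured step touches this position: the one step known concerns the amine side of the core, and its size says nothing about the amide aryl. With nothing in the series that bears on the change, the expectation in this assay is a step within the scatter, in no fixed direction, which is what the estimate a 1.1-fold lower number from compound 2 to compound 4 (0.05 log units; within the scatter) means. Compound 4 is therefore expected to give about 26000 nM, between 8000 nM and 85000 nM.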

Compound 4, half-maximal inhibitory concentration: 15700 nM
For compound 4 the middle estimate is 1.7-fold (0.22 log units) above the measured one, within the range that was stated.
By their numbers in this assay, from the lowest: compound 1; then compounds 4, 2 and 3 (each within the scatter of the next, the first and the last beyond it).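

In this assay the amide aryl now has its first measured step: methoxy in place of methyl, on an aromatic carbon ortho to a large group, gives a 1.9-fold lower number from compound 2 to compound 4 (0.27 log units; within the scatter) and so stays within the usual scatter. At this position, then, the 2-methylphenyl and 2-methoxyphenyl forms are not separated by this read-out, even though methoxy brings a hydrogen-bond acceptor that methyl does not have. No measurement in hand bears on why the two compounds read alike, and no cause can be given.

Going by these compounds, it remains open whether a hydroxyl, an amine or a longer ethoxy chain on the same carbon would also stay within the scatter of compound 2. On these data alone, it is equally open whether methoxy for methyl would read the same with the (2-(dimethylamino)ethyl)amino group of compound 1 on the core.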